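The compounds below may be only part of what the source reports. "The series", "measured", "known", "first", "only" and "open" are said of these compounds alone.

In a functional assay on A549 cells (Homo sapiens) for antiproliferative activity, read by XTT assay, with a stated time of 72 h (a higher number here means a weaker inhibitor, a lower number a stronger inhibitor), compound 1 (`C=C(C)CC[C@]1(C)C2=CCC[C@](C)(C[C@H](O)c3ccoc3)[C@H]2CC[C@H]1C`) gives 34000 nM, compound 2 (`C=C(C)CC[C@]1(C)C2=CCC[C@](C)(C[C@@H](O)C3=CC(=O)OC3O)[C@H]2CC[C@H]1C`) gives 4400 nM and compound 3 (`C=C(C)CCC[C@]1(C)C2=CCC[C@](C)(C[C@H](O)C3=CC(=O)OC3O)[C@H]2CC[C@H]1C`) gives 3200 nM. Compound 3 thus sits within the scatter of compound 2 and clearly under compound 1. Compound 4 (`C=C(C)CC[C@]1(C)C2=CCC[C@](C)(C[C@H](O)C3=CC(=O)OC3O)[C@H]2CC[C@H]1C`) differs from compound 3 as follows: 1-methylethenyl in place of 2-methylprop-2-en-1-yl on a saturated chain carbon, two bonds along the chain from a saturated ring carbon. In words, 1-methylethenyl stands in place of 2-methylprop-2-en-1-yl on a saturated chain carbon, two bonds along the chain from a saturated ring carbon. Going by the values given here, the only measured step, a 7.7-fold lower number from compound 1 to compound 2 (0.89 log units; beyond the scatter), changes a different group and leaves this chain untouched, so it gives no size for this change. No step beyond the scatter is therefore expected in this assay. The estimated step is a 1.1-fold higher number from compound 3 to compound 4 (0.05 log units; within the scatter). The expected value for compound 4 is 3600 nM, with an estimated range of 1800 nM to 7500 nM.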

Compound 4, half-maximal inhibitory concentration: 4500 nM
Estimate against measurement, compound 4: 1.3-fold (0.10 log units) below; low and high end bracket the measured number.
By their numbers in this assay, from the lowest: compounds 3, 2 and 4 (each within the scatter of the next); then compound 1.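

In this assay, 1-methylethenyl in place of 2-methylprop-2-en-1-yl on a saturated chain carbon, two bonds along the chain from a saturated ring carbon, gives a 1.4-fold higher number from compound 3 to compound 4 (0.15 log units; within the scatter), so this change leaves the number within the scatter. The drawn stereocentre at a saturated chain carbon gives a 1.0-fold higher number from compound 2 to compound 4 (0.01 log units; within the scatter), a reading that carries one caveat: the fact that one of compounds 2 and 4 is drawn with a defined configuration and the other without, at the place where they differ. With the chain held, the five-membered non-aromatic ring group in place of the five-membered aromatic ring group gives a 7.6-fold lower number from compound 1 to compound 4 (0.88 log units; beyond the scatter).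

Open, as far as these compounds go, is whether a carboxylic acid or an amine at the end of this chain would keep the number.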